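A few compounds are considered here, and "the series" means these few. Any claim that something is new, unique, unknown or untested is made for them only; others in the source may bear on it.

Compound 1 `Cc1cccc(C)c1NN=C1CCC(C)n2c1ncc(C(=O)O)c2=O` carries a 2,6-dimethylphenyl on an amine nitrogen of the shared core, and in a functional assay on the whole organism with Rattus norvegicus as the target (on this read-out higher numbers stand for an effect only at larger amounts of compound and lower numbers for an effect already at smaller amounts), compound 1 gives 320 umol/kg. Compound 2 `CC1CCC(=NNc2cc(Cl)cc(Cl)c2)c2ncc(C(=O)O)c(=O)n21` carries a 3,5-dichlorophenyl on that amine nitrogen instead. In this assay compound 2 gives only a limit of the assay, > 100 umol/kg, and not a number. The step that the limit leaves unreadable from compound 1 to compound 2 therefore has no readable size, since the limit of > 100 umol/kg in this assay, at which 1 of the 2 values shown sits, leaves one end open. Compound 3 `CC1CCC(=NNc2c(Cl)cccc2Cl)c2ncc(C(=O)O)c(=O)n21` is built from the same atoms as compound 2, joined differently: 2,6-dichlorophenyl in place of 3,5-dichlorophenyl on an amine nitrogen. For the measured compounds named here, no measured step in this assay pairs these two chlorine arrangements with numbers on both sides, so the single step on record gives neither a direction nor a size to carry over. Going by the values given here, the only firm number nearby belongs to compound 1, whose 2,6-dimethylphenyl resembles the 2,6-dichlorophenyl of compound 3. Compound 3 is therefore expected to land near the value of compound 1 320 umol/kg, with wide uncertainty. For compound 3 the estimate in this assay is 250 umol/kg, ranging from 60 umol/kg to 1000 umol/kg. The step that the limit leaves unreadable from compound 2 to compound 3 is expected to be unreadable in size, given the open limit of compound 2.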

Compound 3, dose for 50% inhibition: > 100 umol/kg
Compound 3 gave a limit, no number; the forecaster's own chance of this, stated with the estimate: 50%; the middle value does not contradict the limit.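

No new step can be read between compound 3 and either compound 1 or compound 2, because compound 2 and compound 3 both give only a limit and not a number: the limit of > 100 umol/kg in this assay, at which 2 of the 3 values shown sit. The compounds shown leave open whether 3,5-dichlorophenyl and 2,6-dichlorophenyl differ at all in this assay, and how either compares with 2,6-dimethylphenyl.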